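The compounds below may be only part of what the source reports. "The series", "measured", "known", "first", "only" and "open" are said of these compounds alone.

Three compounds share one core, joined through a linker to a ring amine that carries an aromatic group. In an assay on HEK293 cells for displacement of a labelled ligand from 5-hydroxytryptamine receptor 6 (Homo sapiens) (on this read-out higher numbers stand for weaker inhibition and lower numbers for stronger inhibition), compound 1 `COc1ccccc1N1CCN(Cc2ccc(CN3C(=O)c4ccccc4S3(=O)=O)cc2)CC1` gives 10100 nM, compound 2 `O=C1c2ccccc2S(=O)(=O)N1CCCCCCN1CCN(c2ncccn2)CC1` gives 5710 nM, and compound 3 `COc1ccccc1N1CCN(CCCCCN2C(=O)c3ccccc3S2(=O)=O)CC1` gives 1990 nM. Compound 3 has the lowest of the three numbers; its gap to compound 2 and its wider gap to compound 1 both lie beyond the usual scatter, so among these three it is the strongest binder. Compound 4 `O=C1c2ccccc2S(=O)(=O)N1CCCCCN1CCN(c2cccc(C(F)(F)F)c2)CC1` differs from compound 3 in one place: 3-(trifluoromethyl)phenyl in place of 2-methoxyphenyl on an amine nitrogen in a ring. Among the compounds with values here, no measured pair isolates this swap, so the step expected from compound 3 to compound 4 is a 1.3-fold higher number from compound 3 to compound 4 (0.10 log units; within the scatter), with no change beyond the scatter in either direction. Compound 4 is therefore estimated at 2500 nM, within a range from 700 nM to 9000 nM.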

Compound 4, inhibition constant: 1350 nM
For compound 4 the middle estimate is 1.9-fold (0.27 log units) above the measured one; measured number inside the range.
By their numbers in this assay, from the lowest: compounds 4 and 3 (each within the scatter of the next); then compounds 2 and 1 (each within the scatter of the next).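

Putting 3-(trifluoromethyl)phenyl in place of 2-methoxyphenyl on the ring amine nitrogen gives a 1.5-fold lower number from compound 3 to compound 4 (0.17 log units; within the scatter) in this assay so the two compounds read alike. This position therefore accepts either aromatic group in this pair, even though the hydrogen-bond acceptor counted on 2-methoxyphenyl is absent from the group that enters. Nothing measured here explains why the two groups read alike.

Going by these compounds, whether a plain phenyl group, carrying neither methoxy nor trifluoromethyl, would read the same on this nitrogen stays open. So does the effect of a chlorine on that phenyl ring.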